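The source may hold more compounds than are shown below. What is called first, only, known or untested is meant among the compounds shown, and "the series" means these compounds.

Measured compounds in a functional assay on CCRF-CEM cells for antagonist activity at C-X-C chemokine receptor type 4 (Homo sapiens), read by calcium flux, with stated times of 25 min and 90 s; a higher number here means a weaker inhibitor, a lower number a stronger inhibitor:
compound 1 `c1ccc2c(c1)CN[C@@H](CN(CC1CCNCC1)[C@H]1CCCc3cccnc31)C2`, for which compound 1 gives 65 nM
compound 2 `c1ccc2c(c1)CN[C@@H](CN(CC[C@@H]1CCCNC1)[C@H]1CCCc3cccnc31)C2`, for which compound 2 gives 161 nM
compound 3 `c1ccc2c(c1)CN[C@@H](CN(CCC1CCNCC1)[C@H]1CCCc3cccnc31)C2`, for which compound 3 gives 150 nM

Compound 3 holds the second highest of the three numbers in this assay. The step of a 1.1-fold lower number from compound 2 to compound 3 (0.03 log units; within the scatter) lies within the scatter, so compound 2 and compound 3 cannot be separated; the step of a 2.3-fold higher number from compound 1 to compound 3 (0.36 log units; beyond the scatter) lies beyond it.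

Compound 4 `CCN1CCN(CCCN(C[C@H]2Cc3ccccc3CN2)[C@H]2CCCc3cccnc32)CC1` differs from compound 3 in one place: (4-ethylpiperazin-1-yl)methyl in place of piperidin-4-yl on a saturated chain carbon, two bonds along the chain from an amine nitrogen. Two kinds of measured step bear on this. Exchanging one piperidinyl ring for another at the same place, a 1.1-fold lower number from compound 2 to compound 3 (0.03 log units; within the scatter), left the number unchanged. Lengthening the chain by one carbon, a 2.5-fold higher number from compound 1 to compound 2 (0.39 log units; beyond the scatter) and a 2.3-fold higher number from compound 1 to compound 3 (0.36 log units; beyond the scatter), gave modest higher numbers each time. Among the measured compounds shown here, the move to compound 4 lengthens the chain once more and also replaces the ring by a piperazinyl group, an exchange no measured pair covers. On the chain-lengthening precedent a modest rise in this assay is expected, with wide uncertainty from the untested ring exchange; the expected step is a 1.9-fold higher number from compound 3 to compound 4 (0.27 log units; within the scatter). Compound 4 is therefore estimated at 280 nM in this assay, with a range from 80 nM to 1000 nM.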

Compound 4, half-maximal inhibitory concentration: 33 nM
For compound 4 the middle estimate is 8.5-fold (0.93 log units) above the measured one; measured number outside the range, below it.
By their numbers in this assay, from the lowest: compounds 4 and 1 (each within the scatter of the next); then compounds 3 and 2 (each within the scatter of the next).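

In this assay the place two bonds along the chain from an amine nitrogen takes the 3-(4-ethylpiperazin-1-yl)propyl group with a lower number than the 2-(piperidin-4-yl)ethyl group gives, the step being a 4.5-fold lower number from compound 3 to compound 4 (0.66 log units; beyond the scatter); the exchange from the piperidin-3-yl series gives a 4.9-fold lower number from compound 2 to compound 4 (0.69 log units; beyond the scatter), so among these compounds a longer chain does not by itself bring a higher number. Against the shorter (piperidin-4-yl)methyl group of compound 1 the step is a 2.0-fold lower number from compound 1 to compound 4 (0.29 log units; within the scatter), so the rise seen on lengthening the chain with a piperidinyl ring, in compound 2 and compound 3, does not carry over to compound 4, which cannot be separated from compound 1. No measurement at hand accounts for this reversal.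

The compounds shown leave the ring, its ethyl group and the chain length changed together, so a piperazin-1-yl or 4-methylpiperazin-1-yl group on the same chain would be needed to tell these apart. From the compounds shown here alone, it also remains open how the 4-ethylpiperazin-1-yl group behaves on a shorter chain, and whether a morpholine ring at its place would hold the number.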